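Adding two more fluorines to the aryl group of compound 2

The compounds below may be only part of what the source reports. "The series", "measured", "known", "first", "only" and "open" are said of these compounds alone.

In a functional assay on EBC-1 cells (Homo sapiens) for antiproliferative activity, with a stated time of 72 h (a higher number here means a weaker inhibitor, a lower number a stronger inhibitor), compound 2 `COc1ccc2c(OCc3nnc4sc(-c5ccc(F)cc5)nn34)ccnc2c1` gives 187 nM. Among the compounds with values here, compound 1 `COc1ccc2c(OCc3nnc4sc(-c5cc6ccccc6n5C)nn34)ccnc2c1` gives 149 nM, and the step of a 1.3-fold higher number from compound 1 to compound 2 (0.10 log units; within the scatter) is within the scatter, so the two numbers so far sit close together. Compound 3 `COc1ccc2c(OCc3nnc4sc(-c5cc(F)c(F)c(F)c5)nn34)ccnc2c1` carries 3,4,5-trifluorophenyl in place of 4-fluorophenyl on an aromatic carbon. Within the data shown here, no measured step adds fluorines to an aryl group; the one known step exchanges the whole aryl group and was small, so no step beyond the scatter is expected in this assay. Compound 3 is therefore estimated at 220 nM, range 90 nM to 550 nM, an expected step of a 1.2-fold higher number from compound 2 to compound 3 (0.07 log units; within the scatter).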

Compound 3, half-maximal inhibitory concentration: 403 nM
Compound 3: the middle estimate sits 1.8-fold (0.26 log units) below what was measured; the range from low to high includes it.
By their numbers in this assay, from the lowest: compounds 1 and 2 (each within the scatter of the next); then compound 3.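

At this aromatic carbon, this assay now shows a change beyond the scatter: 3,4,5-trifluorophenyl in place of 4-fluorophenyl gives a 2.2-fold higher number from compound 2 to compound 3 (0.33 log units; beyond the scatter) and the earlier exchange of aryl groups did not. Set against the 1-methyl-1H-indol-2-yl group, the same replacement gives a 2.7-fold higher number from compound 1 to compound 3 (0.43 log units; beyond the scatter) so the aryl groups here no longer all read alike, though both steps are modest. Nothing available bears on the origin of this rise.

Going by these compounds, whether the number of fluorines or their pattern carries the step stays open. Also open, on these data alone, is how an aryl group bearing an amine or a carboxylic acid would read at this carbon.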